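Saturating the Alkyne Chain on the Shared Core

This account rests on a few compounds, and the source may have more. Where it says the series, first, only, none or still open, it means among the compounds named here.

The measured compounds in a functional assay on L1210 cells (Mus musculus); a lower number here means a stronger inhibitor, a higher number a weaker inhibitor:
Compound 1, `O=c1[nH]c(=O)n([C@H]2C[C@H](O)[C@@H](CO)O2)cc1C#CCCO`, gives only a limit of the assay, > 1000 ug/mL.
Compound 2, `CCCC/C=C\c1cn([C@H]2C[C@H](O)[C@@H](CO)O2)c(=O)[nH]c1=O`, gives 361 ug/mL.
Compound 3, `CCCCCC#Cc1cn([C@H]2C[C@H](O)[C@@H](CO)O2)c(=O)[nH]c1=O`, gives 219 ug/mL.

Compound 3 holds the lowest of the two actual numbers, but its nearest neighbour is compound 2, and the gap a 1.6-fold lower number from compound 2 to compound 3 (0.22 log units; within the scatter) lies within the scatter, so the two cannot be ordered. Compound 1 stands apart as a limit (the limit of > 1000 ug/mL in this assay, at which 1 of the 3 values shown sits), which makes the steps of an at least 2.7-fold lower number from compound 1 to compound 2 (0.44 log units; beyond the scatter) and an at least 4.5-fold lower number from compound 1 to compound 3 (0.65 log units; beyond the scatter) known only as lower bounds on the improvement.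

Compound 4, `CCCCCCc1cn([C@H]2C[C@H](O)[C@@H](CO)O2)c(=O)[nH]c1=O`, is the next point. It differs from compound 3 by the change (hexyl in place of hept-1-yn-1-yl on an aromatic carbon). The step that bears most directly on this is a 1.6-fold lower number from compound 2 to compound 3 (0.22 log units; within the scatter), where a double bond was exchanged for a triple bond on the same aromatic carbon and the number moved by no more than the scatter. Going by the values given here, compound 4 goes one stage further, to a fully saturated chain, and nothing among the measured steps suggests that this will matter much. The step of a 1.4-fold higher number from compound 3 to compound 4 (0.14 log units; within the scatter) is therefore expected to stay within the scatter, if anything drifting toward a slightly higher number. Compound 4 is expected to give about 300 ug/mL, in the range 120 ug/mL to 800 ug/mL.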

Compound 4, concentration for 50% inhibition: 301 ug/mL
Estimate against measurement, compound 4: 1.0-fold (0.00 log units) below; measured number inside the range.
By their numbers in this assay, from the lowest: compounds 3, 4 and 2 (each within the scatter of the next). At a limit, above all of these: compound 1.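

In this assay, hexyl in place of hept-1-yn-1-yl gives a 1.4-fold higher number from compound 3 to compound 4 (0.14 log units; within the scatter), and hexyl in place of hex-1-en-1-yl gives a 1.2-fold lower number from compound 2 to compound 4 (0.08 log units; within the scatter). On this aromatic carbon, then, the fully saturated chain cannot be told apart from the chains carrying a triple or a double bond, so the earlier lack of separation between those two unsaturated chains now extends to a chain with neither. Hexyl in place of 4-hydroxybut-1-yn-1-yl gives an at least 3.3-fold lower number from compound 1 to compound 4 (0.52 log units; beyond the scatter), which is only a lower bound on the size of the step, the starting value being a limit: the limit of > 1000 ug/mL in this assay, at which 1 of the 4 values shown sits.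

What the compounds shown leave open is how far chain length matters at this position, as no shorter chain such as propyl or longer chain such as decyl appears among them. The 4-hydroxybut-1-yn-1-yl group also differs from the other chains in both its length and its hydroxy group, and these compounds do not separate the two, which a hexyl chain ending in a hydroxy group or an amine could address.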